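The compounds below may be only part of what the source reports. "The series", "measured", "known", "first", "only" and "open" are said of these compounds alone.

The compounds here share a core, seen in compound 1 `COc1ccc(C(=O)/C=C/c2ccc3ccccc3c2)c2c1C=CC(C)(C)O2`, to which a chain of two double-bonded carbons and a carbonyl links a second ring. They were tested in a functional assay on K562 cells (Homo sapiens) for antiproliferative activity, read by MTT assay, with a stated time of 24 h; a higher number here means a weaker inhibitor, a lower number a stronger inhibitor. Compound 1 gives 3670 nM. Compound 2 `COc1ccc(C(=O)/C=C/c2ccc(N(c3ccccc3)c3ccccc3)cc2)c2c1C=CC(C)(C)O2` reaches only the limit of this assay, giving > 10000 nM. Compound 3 `COc1ccc(/C=C/C(=O)c2ccc(OC)c3c2OC(C)(C)C=C3)cn1` likewise stops at the limit, giving > 10000 nM. So compound 3 stands among the weaker members of the group, with no number of its own; the limit of > 10000 nM in this assay, at which 2 of the 3 values shown sit, covers two of the three values shown.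

Compound 4 `COc1ccc(C(=O)/C=C/c2cccc(O)c2)c2c1C=CC(C)(C)O2` differs from compound 3 by 3-hydroxyphenyl in place of 6-methoxypyridin-3-yl on a double-bonded chain carbon bound to a double-bonded chain carbon. For the measured compounds named here, no single-change step between measured compounds is available, so the size of this step can only be guessed. Going by the values given here, compound 1 supplies the one numbered value, 3670 nM, and compound 4 is expected to land in the same broad region. The expected step of an at least 1.2-fold lower number from compound 3 to compound 4 (0.09 log units; that floor lies within the scatter) leads toward a measurable value. Compound 4 is expected to give about 8000 nM, within a range of 2500 nM to 20000 nM.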

Compound 4, half-maximal inhibitory concentration: > 10000 nM
Compound 4: a limit, no number; the forecaster's own chance of this, stated with the estimate: 45%; middle value at least 1.2-fold (0.09 log units) from the limit.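

In this assay compound 4 gives > 10000 nM, which is a limit and not a number. For the compounds shown here, compound 3 also sits at a limit, so no step between compound 3 and compound 4 can be read. From the compounds shown here alone, how far 3-hydroxyphenyl and 6-methoxypyridin-3-yl truly differ in this assay stays open.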